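This account rests on a few compounds, and the source may have more. Where it says the series, first, only, none or still open, it means among the compounds named here.

Within the data shown here, in a functional assay on A549 cells (Homo sapiens) for inhibition, read by MTT assay, with a stated time of 24 h (on this read-out higher numbers stand for weaker inhibition and lower numbers for stronger inhibition), two compounds with a shared core have numbers so far: compound 1 `CC1(C)[C@H]2CC[C@]1(C)N(Cc1cn(-c3ccc(F)cc3)nn1)C(=O)C2` gives 230 nM and compound 2 `CC1(C)[C@H]2CC[C@]1(C)N(Cc1cn(-c3cccc(Cl)c3)nn1)C(=O)C2` gives 60 nM as the lower of the two. Next comes compound 3 `CC1(C)[C@H]2CC[C@]1(C)N(Cc1cn(-c3ccc(O)cc3)nn1)C(=O)C2` which has 4-hydroxyphenyl in place of 3-chlorophenyl on an aromatic nitrogen. Among the measured compounds shown here, only one measured step bears on this change, and it sits at the same place: the move a 3.8-fold lower number from compound 1 to compound 2 (0.58 log units; beyond the scatter) is modest but beyond the scatter. For the measured compounds named here, no compound with a hydroxyl group has been measured yet, so this guide is thin. Judging from compound 1 at 230 nM a modest step toward a higher number is expected in this assay once 3-chlorophenyl is gone. The expected change is a 4.0-fold higher number from compound 2 to compound 3 (0.60 log units; beyond the scatter) by this estimate. Compound 3 is estimated at 240 nM with an expected range from 60 nM to 900 nM for its measurement.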

Compound 3, half-maximal inhibitory concentration: 140 nM
Estimate against measurement, compound 3: 1.7-fold (0.23 log units) above, and the stated range covers the measured number.
By their numbers in this assay, from the lowest: compound 2; then compounds 3 and 1 (each within the scatter of the next).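

In this assay, the step with 4-hydroxyphenyl in place of 3-chlorophenyl is a 2.3-fold higher number from compound 2 to compound 3 (0.37 log units; beyond the scatter), so a second group on this ring also gives a higher number than compound 2. Hydroxy in place of fluoro on an aromatic carbon gives a 1.6-fold lower number from compound 1 to compound 3 (0.22 log units; within the scatter), so this position does not separate these two groups, even though the hydroxy group adds a hydrogen-bond donor and the step stays within the scatter. No supporting measurement is available to explain either step.

As far as these compounds go, it remains open whether the lower number of compound 2 goes with the chlorine itself or with its place on the ring, as both differ from compound 1 and compound 3. A 4-chlorophenyl or 3-hydroxyphenyl group would pull these two apart, and a 3-aminophenyl group would extend the comparison to an amine.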